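Cyclopropylmethoxy to ethoxy: from compound 2 to compound 4

A few compounds are considered here, and "the series" means these few. Any claim that something is new, unique, unknown or untested is made for them only; others in the source may bear on it.

Measured so far in an ADME assay on the whole organism (blood, strain Han-Wistar) for pharmacokinetics, with Rattus norvegicus as the target, read by LC-MS, at a dose of 1 mg/kg by the intravenous route (on this read-out lower numbers stand for slow clearance and higher numbers for fast clearance), for three compounds:
compound 1 `O=C(O)CCn1c(=O)oc2cc(Cl)c(Cl)cc21` gives 4.3 mL/min/kg
compound 2 `O=C(O)CCn1c(=O)oc2cc(OCC3CC3)c(Cl)cc21` gives 4.1 mL/min/kg
compound 3 `C[C@@H](Oc1cc2onc(CCC(=O)O)c2cc1Cl)c1ccc(Cl)cn1` gives 0.35 mL/min/kg

Compound 2 sits within the scatter of compound 1, and both lie well apart from compound 3, whose number is beyond the scatter from that of compound 2 on the low side. The next compound is compound 4 `CCOc1cc2oc(=O)n(CCC(=O)O)c2cc1Cl`, reached by methyl in place of cyclopropyl on a saturated chain carbon bound to an oxygen on an aromatic ring, so that cyclopropylmethoxy becomes ethoxy.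

Among the compounds with values here, one measured step bears on this: a 1.0-fold lower number from compound 1 to compound 2 (0.02 log units; within the scatter), with cyclopropylmethoxy in place of chloro on an aromatic carbon, stayed within the scatter. Within the data shown here, no measured step isolates the exchange of cyclopropyl for methyl itself, so this remains indirect evidence. Bringing in the whole cyclopropylmethoxy group moved the number by no more than the scatter, and trimming that group to ethoxy is therefore not expected to do more. The estimated change is a 1.0-fold lower number from compound 2 to compound 4 (0.01 log units; within the scatter) in this assay and is expected to stay within the scatter. For compound 4 the estimate is 4 mL/min/kg, with 2 mL/min/kg to 8 mL/min/kg as the expected range.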

Compound 4, clearance: 16 mL/min/kg
For compound 4 the middle estimate is 4.0-fold (0.60 log units) below the measured one; the measured number lies above the stated range.
By their numbers in this assay, from the lowest: compound 3; then compounds 2 and 1 (each within the scatter of the next); then compound 4.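

In this assay this position proves sensitive to the group it carries: the earlier step (a 1.0-fold lower number from compound 1 to compound 2 (0.02 log units; within the scatter)) left the number unchanged within the scatter, whereas methyl in place of cyclopropyl on a saturated chain carbon bound to an oxygen on an aromatic ring gives a step beyond it (a 3.9-fold higher number from compound 2 to compound 4 (0.59 log units; beyond the scatter)). Ethoxy in place of chloro on an aromatic carbon also gives a step beyond the scatter (a 3.7-fold higher number from compound 1 to compound 4 (0.57 log units; beyond the scatter)), so ethoxy stands apart on the high side while chloro and cyclopropylmethoxy stay within the scatter of each other on the shared core. Nothing among the data shown accounts for the difference between ethoxy and cyclopropylmethoxy.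

Open, on these data alone, is whether a methoxy or an unbranched propoxy at this place would fall with ethoxy or with cyclopropylmethoxy, which would help separate the loss of the three-membered ring from the shortening of the chain. Also open, as far as these compounds go, is whether the same exchange would give a step of like size on the core of compound 3.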